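Swapping chloro for methoxy on the ethoxy-bearing ring

The source may hold more compounds than are shown below. What is called first, only, known or untested is meant among the compounds shown, and "the series" means these compounds.

Compound 1 `CCOc1cc(-c2cc3c(O)nc(C)nc3cc2C(C)C)ccc1Cl` is the stronger of the two compounds measured in a functional assay for inhibition of transient receptor potential cation channel subfamily V member 1 (Homo sapiens), read by fluorescence and calcium flux; a higher number here means a weaker inhibitor, a lower number a stronger inhibitor: compound 1 gives 12 nM. Compound 2 `CCCCOc1cc(-c2cc3c(O)nc(C)nc3cc2C(C)C)ccc1Cl` gives 82 nM in this assay. That single measured step, a 6.8-fold higher number from compound 1 to compound 2 (0.83 log units; beyond the scatter), comes from an ethyl added on the alkoxy chain, not from the position now changed. Compound 3 `CCOc1cc(-c2cc3c(O)nc(C)nc3cc2C(C)C)ccc1OC` differs from compound 1 by methoxy in place of chloro on an aromatic carbon. Within the data shown here, no measured step bears on this swap, so the expectation rests on the structural change alone. A modest weakening is expected, a 3.3-fold higher number from compound 1 to compound 3 (0.52 log units; beyond the scatter). Compound 3 is therefore estimated at 40 nM, with a likely range from 10 nM to 160 nM.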

Compound 3, half-maximal inhibitory concentration: 286 nM
Beside the measured number, compound 3's estimate is 7.2-fold (0.85 log units) below it; the whole stated range lies below it.
By their numbers in this assay, from the lowest: compound 1; then compound 2; then compound 3.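

At this aromatic carbon, ortho to an ethoxy group, methoxy in place of chloro gives a 24-fold higher number from compound 1 to compound 3 (1.38 log units; beyond the scatter) in this assay and shows that this ring position responds strongly to a single change. This step on the ring is larger than a 6.8-fold higher number from compound 1 to compound 2 (0.83 log units; beyond the scatter) on the alkoxy chain. Nothing measured here accounts for the size of the ring step.

Going by these compounds, whether fluoro, bromo or methyl at this place would match compound 1 remains open. So does whether the same swap would have a similar effect alongside the longer butoxy chain of compound 2.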